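The compounds below may be only part of what the source reports. "The series", "measured", "known", "first", "only" and "open" are said of these compounds alone.

Working notes on the series. Compound 1 `Nc1ccn([C@@H]2O[C@H](CO)[C@@H](Br)[C@@H]2O)c(=O)n1` carries a bromo on a saturated ring carbon; in a functional assay on L5178Y cells (Mus musculus) for inhibition (a higher number here means a weaker inhibitor, a lower number a stronger inhibitor), compound 1 gives 10 ug/mL. Among the measured compounds shown here, compound 2 `Nc1ccn([C@@H]2O[C@H](CO)[C@@H](I)[C@@H]2O)c(=O)n1` carries iodo in the same place and in this assay compound 2 gives 1 ug/mL, the lowest of the two numbers so far, with a 10-fold lower number from compound 1 to compound 2 (1.00 log units; beyond the scatter) as the only step in hand. Compound 3 `[N-]=[N+]=N[C@H]1[C@H](O)[C@H](n2ccc(N)nc2=O)O[C@@H]1CO` differs from compound 2 by azido in place of iodo on a saturated ring carbon. For the measured compounds named here, the one measured step concerns a halogen swap and does not cover an azido group, so for compound 3 a step of a 3.0-fold higher number from compound 2 to compound 3 (0.48 log units; beyond the scatter) is expected only loosely. Compound 3 is estimated at 3 ug/mL, between 0.3 ug/mL and 30 ug/mL.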

Compound 3, concentration for 50% inhibition: 0.5 ug/mL
Compound 3: the middle estimate sits 6.0-fold (0.78 log units) above what was measured, and the stated range covers the measured number.
By their numbers in this assay, from the lowest: compounds 3 and 2 (each within the scatter of the next); then compound 1.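

At this saturated ring carbon a halogen is not required for a low number: azido in place of iodo gives a 2.0-fold lower number from compound 2 to compound 3 (0.30 log units; within the scatter) in this assay, so compound 2 and compound 3 cannot be told apart. Azido in place of bromo gives a 20-fold lower number from compound 1 to compound 3 (1.30 log units; beyond the scatter) and thus sets compound 3 clearly apart from compound 1. Nothing available explains these results.

Open, going by these compounds, is how an amine or a chloro at the same ring carbon would read in this assay. The compounds shown also cannot say whether a longer chain would be tolerated there.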